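Shortening a Hydroxypentynyl Chain to Hydroxy on Deoxyuridine

The source may hold more compounds than are shown below. What is called first, only, known or untested is meant among the compounds shown, and "the series" means these compounds.

Measured compounds in an ADME assay on L1210/0 cells (Mus musculus) for cytotoxicity, with a stated time of 48 h; on this read-out higher numbers stand for weaker inhibition and lower numbers for stronger inhibition:
compound 1 `OC[C@@H]1C[C@H](Cn2cnc3c(NC4CCC4)ncnc32)c2c(-c3ccccc3)nnc(-c3ccccc3)c21` — 90800 nM
compound 2 `O=c1[nH]c(=O)n([C@H]2C[C@H](O)[C@@H](CO)O2)cc1C#CCCCO` — only a limit of the assay, > 200000 nM
compound 3 `Cc1ccc(S(=O)(=O)OCCC#Cc2cn([C@H]3C[C@H](O)[C@@H](CO)O3)c(=O)[nH]c2=O)cc1` — only a limit of the assay, > 200000 nM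

Compound 2 therefore stands at the edge of what this assay can report, not at a number, and it shares that position with one other compound, (the limit of > 200000 nM in this assay, at which 2 of the 3 values shown sit). Only compound 1 gives an actual value, and it is a weak one.

Compound 4 `O=c1[nH]c(=O)n([C@H]2C[C@H](O)[C@@H](CO)O2)cc1O` keeps the whole sugar and base of compound 2 and changes one thing: hydroxy in place of 5-hydroxypent-1-yn-1-yl on an aromatic carbon. Within the data shown here, no measured pair shows what such a change does here, so the expected step of a number no higher from compound 2 to compound 4 (the limit leaves the size open) is none beyond the scatter, with compound 4 most likely again reported as a limit. Compound 4 is estimated at 200000 nM, between 60000 nM and 600000 nM.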

Compound 4, half-maximal inhibitory concentration: > 200000 nM
Compound 4: only a limit was reported (the forecaster's own chance of this, stated with the estimate: 70%); the middle value lies on the limit itself.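

Compound 2 and compound 4 both end at a reported limit, not a number, so no step can be read between them: the limit of > 200000 nM in this assay, at which 3 of the 4 values shown sit.

From the compounds shown here alone, whether hydroxy in place of 5-hydroxypent-1-yn-1-yl changes inhibition at all stays open.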